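This account rests on a few compounds, and the source may have more. Where it says the series, first, only, none or still open, it means among the compounds named here.

- compound 1 `N#C/C(=C\c1ccccc1OS(=O)(=O)c1ccc(Cl)cc1)C(=O)Nc1nnc(Cc2cccc3ccccc23)s1` with 15%
- compound 2 `N#C/C(=C\c1ccccc1OS(=O)(=O)c1ccc(Cl)cc1)C(=O)Nc1nnc(Cc2ccccc2)s1` with 26%

Going by the values given here, in a functional assay on HL-60 cells (Homo sapiens) for inhibition, read by CCK-8 assay, with a stated time of 48 h, tested at 20 uM (a higher number here means more inhibition of growth at the concentration tested, a lower number less inhibition of growth), compound 2 gives 26% and holds the higher of the two numbers so far, ahead of compound 1 at 15% by a margin beyond the scatter. Still unmeasured is compound 3 `N#C/C(=C\c1ccccc1OS(=O)(=O)c1ccc(Cl)cc1)C(=O)Nc1nnc(-c2cccc(F)c2)s1` which keeps the shared core and differs from compound 2 in one group: 3-fluorophenyl in place of benzyl on an aromatic carbon so that 3-fluorophenyl stands in place of benzyl on an aromatic carbon.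

Among the compounds with values here, only one measured step bears on this, and only loosely: a number 11 percentage points higher from compound 1 to compound 2 (beyond the scatter) is the change of naphthalen-1-yl to phenyl on a saturated chain carbon, and it was modest. Within the data shown here, no measured step shows what happens when benzyl itself is replaced, so the data give no firm direction. Among the measured compounds shown here, with only that modest step as a guide, no step beyond the scatter is expected here, and the estimate leans only slightly upward. The estimated change is a number 4 percentage points higher from compound 2 to compound 3 (within the scatter) and this remains an expectation. For compound 3 the estimated value is 30% with an expected range from 12% to 55% in this assay once it is measured.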

Compound 3, percent growth inhibition at one concentration: 42%
Beside the measured number, compound 3's estimate is 12 percentage points below it, and the stated range covers the measured number.
By their numbers in this assay, from the lowest: compound 1; then compound 2; then compound 3.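

Going by these compounds alone, this is the first measured change made directly on the aromatic carbon of the five-membered ring, and in this assay it brings a number 16 percentage points higher from compound 2 to compound 3 (beyond the scatter) and so shows that the group held at this carbon can move growth inhibition. Set against the (naphthalen-1-yl)methyl group at the same carbon, 3-fluorophenyl gives a number 27 percentage points higher from compound 1 to compound 3 (beyond the scatter) and makes compound 3 the most inhibitory of the three compounds at the single concentration tested. The swap from benzyl removes the saturated carbon link and adds a fluorine in one move while leaving the heavy-atom count unchanged, and nothing measured here explains the rise.

On these data alone, whether the gain follows from the ring standing directly on the aromatic carbon or from the fluorine remains open, and an unsubstituted phenyl at that carbon would separate the two. As far as these compounds go, how an amine or a carboxylic acid on that ring would behave in this assay also remains open.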